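The source may hold more compounds than are shown below. What is called first, only, known or untested is meant among the compounds shown, and "the series" means these compounds.

Working notes on the series. The compounds share one core and differ only in the group on a nitrogen on an aromatic ring. Compound 1 `CCCCCCNc1nc(SCc2ccc(C(F)(F)F)cc2)nc2ccccc12` in a functional assay on PC-3 cells (Homo sapiens) for cytotoxicity, read by MTT assay, with a stated time of 72 h (on this read-out lower numbers stand for stronger inhibition and higher numbers for weaker inhibition), gives 19000 nM. Compound 2 `FC(F)(F)c1ccc(CSc2nc(Nc3ccccc3Cl)c3ccccc3n2)cc1` gives 20400 nM. Compound 3 `O=[N+]([O-])c1cccc(Nc2nc(SCc3ccc(C(F)(F)F)cc3)nc3ccccc23)c1` gives 13500 nM. On the numbers shown, compound 3 is separated from its neighbours by a 1.4-fold lower number from compound 1 to compound 3 (0.15 log units; within the scatter) and by a 1.5-fold lower number from compound 2 to compound 3 (0.18 log units; within the scatter), and the remaining step, a 1.1-fold higher number from compound 1 to compound 2 (0.03 log units; within the scatter), is likewise small; none of the three exchanges at this nitrogen has moved the read-out beyond the scatter.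

Compound 4 `FC(F)(F)c1ccc(CSc2nc(Nc3ccc(Cl)cc3)c3ccccc3n2)cc1` is not yet measured. Its change from compound 3 is 4-chlorophenyl in place of 3-nitrophenyl on a nitrogen on an aromatic ring. The two steps that bear on it are the exchanges of the group on this nitrogen that end at compound 3, from compound 1 and from compound 2, and both stayed within the scatter. No step beyond the scatter is therefore expected in this assay in either direction. For compound 4 the estimated value is 16000 nM, with a range of 7000 nM to 38000 nM. The expected step from compound 3 is a 1.2-fold higher number from compound 3 to compound 4 (0.07 log units; within the scatter).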

Compound 4, half-maximal inhibitory concentration: 7110 nM
Compound 4: middle estimate off by 2.3-fold (0.35 log units), on the high side, and the stated range covers the measured number.
By their numbers in this assay, from the lowest: compounds 4, 3, 1 and 2 (each within the scatter of the next, the first and the last beyond it).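

In this assay, going by these compounds alone, this nitrogen no longer looks silent: 4-chlorophenyl in place of 2-chlorophenyl (a 2.9-fold lower number from compound 2 to compound 4 (0.46 log units; beyond the scatter)) and in place of hexyl (a 2.7-fold lower number from compound 1 to compound 4 (0.43 log units; beyond the scatter)) gives the first steps at this position beyond the scatter, though both are modest. The exchange of 3-nitrophenyl for 4-chlorophenyl (a 1.9-fold lower number from compound 3 to compound 4 (0.28 log units; within the scatter)) stays within the scatter, so compound 3 and compound 4 cannot be ordered, and 4-chlorophenyl stands apart only from 2-chlorophenyl and hexyl. No measurement shown accounts for these steps.

As far as these compounds go, whether an amine or a carboxylic acid on the phenyl ring, or a longer chain on this nitrogen, would extend these steps remains open. Also open, from the compounds shown here alone, is whether they would hold with the trifluoromethyl-bearing part of the shared core replaced.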